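Replacing a tert-butyl amide with a morpholine amide

The source may hold more compounds than are shown below. What is called first, only, known or untested is meant among the compounds shown, and "the series" means these compounds.

Measured so far, in a functional assay on the whole organism (strain Wistar) for inhibition, with Rattus norvegicus as the target, read by paw edema, with stated times of 60 min and 24 h, at a dose of 100 mg/kg by the oral route; a lower number here means less inhibition, a higher number more inhibition at the dose given (going by the name of the read-out):
- compound 1, `COc1cc2c(cc1OC)C(CC(=O)O)CC2`, gives 26.7%
- compound 2, `COc1cc2c(cc1OC)C(CC(N)=O)CC2`, gives 26.7%
- compound 3, `COc1cc2c(cc1OC)C(CC(=O)NC(C)(C)C)CC2`, gives 40%

Compound 3 stands highest of the three numbers in this assay; its steps to both other compounds are beyond the scatter. Going from the acid to the primary amide changed nothing: no change at the digits printed from compound 1 to compound 2 (within the scatter). Putting a tert-butyl group onto the amide nitrogen gave a modest rise: a number 13.3 percentage points higher from compound 2 to compound 3 (beyond the scatter), and the acid-to-tert-butyl-amide step matched it: a number 13.3 percentage points higher from compound 1 to compound 3 (beyond the scatter).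

Compound 4, `COc1cc2c(cc1OC)C(CC(=O)N1CCOCC1)CC2`, differs from compound 3 in one place: morpholin-4-yl in place of (tert-butyl)amino on a carbonyl carbon. Going by the values given here, no measured step covers a ring-closed amide of this kind, so the only guide is that the bare amide in compound 2 sat lower than the substituted one in compound 3. A small drop or no change is expected, so for the step from compound 3 to compound 4 the estimate is a number 7 percentage points lower from compound 3 to compound 4 (within the scatter). Compound 4 is thus expected to give about 33% in this assay, most likely between 15% and 50%.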

Compound 4, a percentage reported as inhibition, in the whole organism at one dose (the size of the read-out at that dose, not a potency): 23.3%
Estimate against measurement, compound 4: 9.7 percentage points above, and the stated range covers the measured number.
By their numbers in this assay, from the lowest: compounds 4, 1 and 2 (each within the scatter of the next); then compound 3.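

In this assay, the rise seen with the tert-butyl amide does not carry over to every substituted amide at this carbonyl carbon: the morpholine amide gives a number 16.7 percentage points lower from compound 3 to compound 4 (beyond the scatter). It also cannot be told apart from the simpler groups, with a number 3.4 percentage points lower from compound 2 to compound 4 (within the scatter) and a number 3.4 percentage points lower from compound 1 to compound 4 (within the scatter), so among these four compounds only the (tert-butyl)amino group stands apart. This swap removes a hydrogen-bond donor and brings in a ring with an added oxygen at the same time, and no measurement here separates those changes or explains the result.

A piperidin-1-yl amide, with a ring lacking that oxygen, could help separate them. A dimethylamino amide, with no ring and no amide hydrogen, leaves open whether the ring itself matters.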